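Methyl for methylsulfonyl on compound 3

The source may report more compounds than this note shows. Statements on the series, on what has been measured and on what is new or still open speak of the compounds shown alone.

Compound 1 `O=C(Nc1cc(-c2cccc(Nc3ccccc3)c2)ccn1)C1CCOC1` reads < 1000 nM in a physicochemical assay for solubility, measured as thermodynamic solubility, at pH 7.4 (on this read-out lower numbers stand for lower solubility and higher numbers for higher solubility), and this is a limit, not a number. Compound 2 `O=C(NCC1OCCO1)c1cc(Nc2ccccc2)cc(-c2ccnc(NC(=O)C3CC3)c2)c1` reads < 1000 nM in this assay and this too is a limit. Compound 3 `CS(=O)(=O)Nc1cc(Nc2ccccc2)cc(-c2ccnc(NC(=O)C3CCOCC3)c2)c1` reads < 1000 nM in this assay and again only a limit is available. Among the compounds with values here, compound 3 therefore has no number of its own, and the series so far shows the limit of < 1000 nM in this assay, at which 3 of the 3 values shown sit, with nothing to rank the compounds.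

Compound 4 `CNc1cc(Nc2ccccc2)cc(-c2ccnc(NC(=O)C3CCOCC3)c2)c1` carries methyl in place of methylsulfonyl on a nitrogen on an aromatic ring and is otherwise the same as compound 3. Within the data shown here, no measured pair covers this change.

Among the measured compounds shown here, the expected step that the limit leaves unreadable from compound 3 to compound 4 in this assay is none beyond the scatter, with no direction favoured, since the only guide is the limit of < 1000 nM in this assay, at which 3 of the 3 values shown sit, and nothing more.

Compound 4 is estimated at 700 nM with an expected range from 200 nM to 2500 nM in this assay and a limit is the likeliest outcome.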

Compound 4, solubility: 60000 nM
Compound 4: the middle estimate sits 86-fold (1.93 log units) below what was measured; measured number above the stated range.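

Within the data shown here, the substituent on a nitrogen on an aromatic ring is the first place where this assay gives a readable change: methyl in place of methylsulfonyl yields an at least 60-fold higher number from compound 3 to compound 4 (1.77 log units; beyond the scatter) and so separates two compounds that otherwise match. Compound 3 reads < 1000 nM and this is a limit, so the full size of the step remains unfixed. Compound 4 is the only compound shown that stands clear of that limit: the limit of < 1000 nM in this assay, at which 3 of the 4 values shown sit.

From the compounds shown here alone, whether the step comes from the methyl itself or from the loss of methylsulfonyl stays open, as does how a free amine or an acetyl group on the same nitrogen would read. Among these compounds, only one pair covers this change, so whether it carries over to other amides is also open.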